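The source may hold more compounds than are shown below. What is called first, only, known or untested is meant among the compounds shown, and "the series" means these compounds.

Measured in a functional assay on SW-620 cells (Homo sapiens) for cytotoxicity, read by MTT assay, with a stated time of 72 h; on this read-out lower numbers stand for stronger inhibition and higher numbers for weaker inhibition:
Compound 1 `COc1ccc(/C=C2\CCC/C(=C\c3cccc(OC)c3OC)C2=O)cc1`: 13600 nM
Compound 2 `COc1cccc(/C=C2\CCC/C(=C\c3ccc(O)cc3)C2=O)c1OC`: > 20000 nM
Compound 3 `COc1ccc(/C=C2\CCC/C(=C\c3cccc(Cl)c3)C2=O)cc1OC`: 5100 nM

Compound 2 gives > 20000 nM, which is a limit of the assay and not a number. Of the two true numbers, compound 3 has the lower at 5100 nM. Compound 1 gives 13600 nM, and this gap lies beyond the usual scatter.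

Compound 4 `COc1ccc(/C=C2\CCC/C(=C\c3cccc(Br)c3)C2=O)cc1OC` has not yet been measured in this assay. It differs from compound 3 by a single exchange, bromo in place of chloro on an aromatic carbon. The only measured step among these compounds, an at least 1.4-fold higher number from compound 1 to compound 2 (0.16 log units; that floor lies within the scatter), is a different change, hydrogen in place of methyl on an oxygen on an aromatic ring. Within the data shown here, it therefore gives no direct measure for this exchange, and no measured pair tests it. With nothing pointing either way, no shift beyond the scatter is expected, and the estimated step is a 1.0-fold lower number from compound 3 to compound 4 (0.01 log units; within the scatter). For compound 4 the expected value is 5000 nM, with an estimated range of 2200 nM to 11000 nM.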

Compound 4, half-maximal inhibitory concentration: 4200 nM
Compound 4: the middle estimate sits 1.2-fold (0.08 log units) above what was measured; the measured number falls inside the stated range.
By their numbers in this assay, from the lowest: compounds 4 and 3 (each within the scatter of the next); then compound 1. At a limit, above all of these: compound 2.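

In this assay, among these compounds, bromo in place of chloro is the first measured exchange at this place, on an aromatic carbon of a six-membered aromatic ring of carbon only, meta to a large group. Going from 3-chlorophenyl to 3-bromophenyl gives a 1.2-fold lower number from compound 3 to compound 4 (0.08 log units; within the scatter), so at this place, with the rest of the structure unchanged, these two groups cannot be told apart in this read-out. Nothing in the data shown bears on the reason for this result.

As far as these compounds go, whether an amine, a carboxylic acid or a longer chain at this same place would stay within the scatter of compound 3 or move beyond it remains open. Also open, from the compounds shown here alone, is whether bromo in place of chloro would read the same way with other groups elsewhere on the shared core.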